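The source may report more compounds than this note shows. Statements on the series, on what has been measured and on what is new or still open speak of the compounds shown alone.

In an assay on isolated protein for inhibition of Calpain-1 catalytic subunit (Rattus norvegicus), read by fluorescence (on this read-out higher numbers stand for weaker inhibition and lower numbers for stronger inhibition), three compounds have been measured:

Compound 1, `CCCC[C@H](NS(=O)(=O)c1ccc(F)cc1)C(=O)N[C@H](C=O)CC(C)C`, gives 260 nM.
Compound 2, `CC(C)C[C@@H](C=O)NC(=O)[C@H](C(C)C)N(C)S(=O)(=O)c1ccc(F)cc1`, gives 21000 nM.
Compound 3, `CC(C)C[C@@H](C=O)NC(=O)[C@@H](NS(=O)(=O)c1ccc(Cl)cc1)C(C)C`, gives 31 nM.

Compound 1 sits second highest of these three numbers in this assay: compound 3 is the nearest, with a lower number that lies beyond the scatter, and compound 2 is the furthest, with a much higher number, also beyond the scatter.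

Compound 4, `CCC[C@H](NS(=O)(=O)c1ccc(F)cc1)C(=O)N[C@H](C=O)CC(C)C`, has not yet been measured. It differs from compound 1 in one place: hydrogen in place of methyl on a saturated chain carbon, four bonds along the chain from a carbonyl carbon and a sulfonamide nitrogen. Going by the values given here, no measured pair differs only in this way, so the step can only be estimated. The step from compound 1 to compound 4 in this assay is expected to be a 1.5-fold higher number from compound 1 to compound 4 (0.19 log units; within the scatter), toward weaker inhibition but not clearly beyond the scatter. Compound 4 is therefore estimated at 400 nM, within 150 nM to 1100 nM.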

Compound 4, half-maximal inhibitory concentration: 130 nM
Compound 4: the middle estimate sits 3.1-fold (0.49 log units) above what was measured, outside the stated range (below it).
By their numbers in this assay, from the lowest: compound 3; then compounds 4 and 1 (each within the scatter of the next); then compound 2.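

In this assay the first direct test of this chain gives a 2.0-fold lower number from compound 1 to compound 4 (0.30 log units; within the scatter). Butyl and propyl on this saturated chain carbon therefore cannot be told apart here, which shows that inhibition does not clearly depend on the end methyl of the butyl chain. Nothing on hand explains this result.

Still open, going by these compounds, is how far the chain can be shortened or lengthened, as with an ethyl or a pentyl group. On these data alone, it is also open whether a ring such as cyclohexyl or an amine at the chain end would be accepted at this position.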